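This account rests on a few compounds, and the source may have more. Where it says the series, first, only, none or still open, it means among the compounds named here.

Measured so far in an assay for inhibition of Tryptophan 2,3-dioxygenase (Homo sapiens), with stated times of 10 min and 60 min, tested at 10 uM; a higher number here means a stronger effect of the compound at the concentration tested, a lower number a weaker effect:

- compound 1 `O=[N+]([O-])c1cccc(CNc2cc(Br)cc3[nH]ncc23)c1`: 91%
- compound 2 `O=[N+]([O-])c1cccc(CNc2cc(C(F)(F)F)cc3[nH]ncc23)c1`: 60%
- compound 3 `O=[N+]([O-])c1ccc(CNc2cc(Br)cc3[nH]ncc23)cc1`: 87%

Compound 2 is compound 1 with one change, (trifluoromethyl in place of bromo on an aromatic carbon). In this assay this change produced a number 31 percentage points lower from compound 1 to compound 2 (beyond the scatter), a step well outside the usual scatter. Compound 3 has the same atoms as compound 1 joined differently; the difference between the two cores is not broken down here. In this assay compound 3 gives 87%, and compound 1 gives 91%; the two numbers lie within the scatter of each other, so nothing is made of their order.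

Compound 4 `O=[N+]([O-])c1ccc(CNc2cc(C(F)(F)F)cc3[nH]ncc23)cc1` is not yet measured. It stands to compound 3 as compound 2 stands to compound 1: the change is trifluoromethyl in place of bromo on an aromatic carbon, and the place described for it matches the place described for the change from compound 1 to compound 2 word for word, so it is taken as the same change on a different core.

Going by the values given here, with only one measured instance of this change, the expectation for compound 4 rests on that single step together with the starting point of compound 3. The step from compound 3 to compound 4 in this assay is expected to be a number 31 percentage points lower from compound 3 to compound 4 (beyond the scatter), because a number 31 percentage points lower from compound 1 to compound 2 (beyond the scatter) was seen for the same change and compound 3 starts from 87%. Compound 4 is accordingly expected to give about 56% in this assay. Going by these compounds, the range for compound 4 is estimated to run from 35% to 76%; the transfer of a single step to a second core is untested here, and the range is widened for that.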

Compound 4, a percentage reported as inhibition, at one concentration (the size of the read-out at that concentration, not a potency): 47%
For compound 4 the middle estimate is 9 percentage points above the measured one; the range from low to high includes it.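

In this assay, trifluoromethyl in place of bromo on the second core gives a number 40 percentage points lower from compound 3 to compound 4 (beyond the scatter), and the step matches the one on the first core within the scatter: the same change on two cores in this assay, a number 31 percentage points lower (beyond the scatter) from compound 1 to compound 2 and a number 40 percentage points lower (beyond the scatter) from compound 3 to compound 4, 9 percentage points apart, within the scatter of two such steps. On these two cores, which have the same atoms joined differently, the change therefore carries over in direction and, as far as the scatter allows, in size, so the step seen on one core was a usable guide to the other. This does not establish a rule for the series: it rests on two pairs and one replacement at one place, the read-out is the size of the effect at a single concentration rather than a potency, and nothing here says why the number falls.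

The compounds shown leave open where a chloro, a methyl or a nitrile on the same aromatic carbon would fall relative to bromo and trifluoromethyl. They also leave open whether the step would hold on a core in which the nitro group gives way to a carboxylic acid or an amine, or in which a longer chain forms the link.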